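The source may report more compounds than this note shows. Statements on the series, on what has been measured and on what is new or still open speak of the compounds shown alone.

Compound 1, `CC1(C)[C@H]2CC[C@]1(C)N(Cc1cn(-c3ccccc3Br)nn1)C(=O)C2`, is measured in a functional assay on OVCAR-3 cells (Homo sapiens) for inhibition, read by MTT assay, with a stated time of 24 h (on this read-out higher numbers stand for weaker inhibition and lower numbers for stronger inhibition), at 140 nM, the lowest of the two numbers available, though its nearest neighbour sits within the scatter. That neighbour, compound 2, `CC1(C)[C@H]2CC[C@]1(C)N(Cc1cn(-c3cccc(C#N)c3)nn1)C(=O)C2`, gives 230 nM in this assay, and the step of a 1.6-fold higher number from compound 1 to compound 2 (0.22 log units; within the scatter) is within the scatter. The unmeasured compound 3, `CC1(C)[C@H]2CC[C@]1(C)N(Cc1cn(-c3cccc(Cl)c3)nn1)C(=O)C2`, differs from compound 1 by 3-chlorophenyl in place of 2-bromophenyl on an aromatic nitrogen. For the measured compounds named here, the only measured step that bears on this change is the one from compound 1 to compound 2, which also exchanges the 2-bromophenyl group on the aromatic nitrogen and gives a 1.6-fold higher number from compound 1 to compound 2 (0.22 log units; within the scatter). On that basis the step to compound 3 is expected to be small, most likely a slightly higher number but not beyond the scatter, a 1.3-fold higher number from compound 1 to compound 3 (0.11 log units; within the scatter). Compound 3 is therefore estimated at 180 nM, with a range from 70 nM to 450 nM.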

Compound 3, half-maximal inhibitory concentration: 50 nM
Estimate against measurement, compound 3: 3.6-fold (0.56 log units) above; measured number below the stated range.
By their numbers in this assay, from the lowest: compound 3; then compounds 1 and 2 (each within the scatter of the next).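

In this assay, exchanging the aryl group on the aromatic nitrogen now gives a step beyond the scatter (a 2.8-fold lower number from compound 1 to compound 3 (0.45 log units; beyond the scatter)), whereas the step from compound 1 to compound 2 had stayed within it. Between the two compounds that carry a group on the 3-position of the phenyl ring, chloro in place of cyano on an aromatic carbon gives a step of similar standing (a 4.6-fold lower number from compound 2 to compound 3 (0.66 log units; beyond the scatter)), so the outcome at this position depends on the group carried by the phenyl ring and not only on the ring being there. Nothing measured here accounts for the size of these steps.

The step from compound 1 to compound 3 changes both the halogen and its place on the ring, and the compounds shown cannot separate the two; a 3-bromophenyl or a 2-chlorophenyl compound would do so. Going by these compounds, how a methoxy group, an amine or a carboxylic acid on the same phenyl ring would read in this assay also stays open.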